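This account rests on a few compounds, and the source may have more. Where it says the series, first, only, none or still open, it means among the compounds named here.

Working notes on the series.

Compound 1 `CC(=O)Nc1ccccc1OCc1cc(C)nc(-c2ccccn2)n1` carries an acetamido group on the ring bearing the ether oxygen. In a functional assay on cells for antagonist activity at Free fatty acid receptor 1 (Homo sapiens), read by TR-FRET and inositol phosphate accumulation, with a stated time of 2 h (a lower number here means a stronger inhibitor, a higher number a weaker inhibitor), compound 1 gives > 39800 nM, which is a limit of the assay and not a number. Compound 2 `CC(=O)Nc1ccc(OCc2cc(C)nc(-c3ccccn3)n2)cc1` has the same atoms joined differently; the difference between the two cores is not broken down here. In this assay compound 2 gives > 39800 nM, again a limit rather than a number. Compound 3 `Cc1cc(COc2ccccc2S(C)(=O)=O)nc(-c2ccccn2)n1` replaces the acetamido group with a methylsulfonyl group (methylsulfonyl in place of acetamido on an aromatic carbon). In this assay compound 3 gives > 39800 nM, also a limit. The step from compound 1 to compound 3 is therefore a step that the two limits leave unreadable from compound 1 to compound 3, and the reason it cannot be read is the limit of > 39800 nM in this assay, at which 3 of the 3 values shown sit.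

Compound 4 `Cc1cc(COc2ccc(S(C)(=O)=O)cc2)nc(-c2ccccn2)n1` is not yet measured. It stands to compound 2 as compound 3 stands to compound 1, with one difference in the surroundings: the change methylsulfonyl in place of acetamido on an aromatic carbon sits para to a large group, whereas in compound 3 it sits ortho to a large group, so it is the same kind of change rather than the same change.

The expectation for compound 4 in this assay is a step that the limit leaves unreadable from compound 2 to compound 4, which is expected to leave it at the limit, because compound 2 sits at > 39800 nM and compound 3 at > 39800 nM. Compound 4 is estimated at 60000 nM, with an expected range from 25000 nM to 200000 nM, and most likely only a limit will be reported.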

Compound 4, half-maximal inhibitory concentration: > 39800 nM
Compound 4: no number, only a limit (the forecaster's own chance of this, stated with the estimate: 88%); the middle value is on the limit's open side.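

The step from compound 2 to compound 4 cannot be read, and compound 4 adds no new readable step, because both compounds give a limit of the assay and not a number: the limit of > 39800 nM in this assay, at which 4 of the 4 values shown sit.

The compounds shown leave open how methylsulfonyl and acetamido compare in this assay, and whether any compound on the shared core gives a number there rather than a limit.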